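Isoquinolinyl for benzodioxinyl on the triazole nitrogen

The source may hold more compounds than are shown below. What is called first, only, known or untested is meant among the compounds shown, and "the series" means these compounds.

Measured so far:
compound 1 `O[C@H](COCCOC[C@@H](O)Cc1cn(-c2ccc3c(c2)OCCO3)nn1)Cc1ccc(-c2ccccc2)cc1`: 16500 nM in a functional assay on HCT-116 cells (Homo sapiens) for inhibition, read by MTT assay, with a stated time of 72 h; a higher number here means a weaker inhibitor of growth, a lower number a stronger inhibitor of growth
compound 2 `COC1=C(OC)C(=O)C(CCCCCCn2cc(C[C@H](O)COCCOC[C@@H](O)Cc3ccc(-c4ccccc4)cc3)nn2)=C(C)C1=O`: 5000 nM

Compound 1 gives the highest of the two numbers; compound 2 sits lower, and the gap between them lies beyond the scatter. Going by the values given here, no pair differing in one place has been measured, so no calibrated step exists. Compound 3 `O[C@H](COCCOC[C@@H](O)Cc1cn(-c2cncc3ccccc23)nn1)Cc1ccc(-c2ccccc2)cc1` differs from compound 1 by isoquinolin-4-yl in place of 2,3-dihydro-1,4-benzodioxin-6-yl on an aromatic nitrogen. With nothing comparable measured, a small step in this assay is expected, toward a lower number but probably within the scatter: a 1.4-fold lower number from compound 1 to compound 3 (0.14 log units; within the scatter). Compound 3 is estimated at 12000 nM, with a range from 4000 nM to 40000 nM.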

Compound 3, concentration for 50% growth inhibition: 17800 nM
Estimate against measurement, compound 3: 1.5-fold (0.17 log units) below, and the stated range covers the measured number.
By their numbers in this assay, from the lowest: compound 2; then compounds 1 and 3 (each within the scatter of the next).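

In this assay, going by these compounds alone, isoquinolin-4-yl in place of 2,3-dihydro-1,4-benzodioxin-6-yl on the aromatic nitrogen gives a 1.1-fold higher number from compound 1 to compound 3 (0.03 log units; within the scatter), the first calibrated step. At this position, therefore, exchanging these two groups of 10 heavy atoms, including the change from two ring oxygens to one ring nitrogen, leaves the growth-inhibition reading unresolved from that of compound 1. Nothing available explains this result.

From the compounds shown here alone, whether an amine or a carboxylic acid on the group at this nitrogen would move the number beyond the scatter remains open. Going by these compounds, the effect of a longer chain between the triazole and an aromatic ring also remains open.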